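Phenyl for pyridin-3-yl on the amide of compound 3

A few compounds are considered here, and "the series" means these few. Any claim that something is new, unique, unknown or untested is made for them only; others in the source may bear on it.

Compound 1 (`CN(c1ccccc1)c1cnc(NCc2c(F)ccc3c2CCO3)n2cnnc12`) gives 55 mL.min-1.g-1 in this series
Compound 2 (`CN(c1ccn(C)n1)c1cnc(NCc2c(F)ccc3c2CCO3)n2cnnc12`) gives 11 mL.min-1.g-1 in this series
Compound 3 (`O=C(Nc1cnc(NCc2c(F)ccc3c2CCO3)n2cnnc12)c1cccnc1`) gives < 3 mL.min-1.g-1 as a limit, not a number

In an ADME assay on microsomes from liver (Homo sapiens) for metabolic stability, read by LC-MS, using NADPH, with stated times of 5 min and 30 min, tested at 1 uM (on this read-out lower numbers stand for slow clearance and higher numbers for fast clearance), compound 3 stands lowest of the three, at a limit and not a number (the limit of < 3 mL.min-1.g-1 in this assay, at which 1 of the 3 values shown sits). Compound 4 (`O=C(Nc1cnc(NCc2c(F)ccc3c2CCO3)n2cnnc12)c1ccccc1`) carries phenyl in place of pyridin-3-yl on a carbonyl carbon. Among the measured compounds shown here, no measured step makes this swap. The two larger steps (an at least 18-fold lower number from compound 1 to compound 3 (1.26 log units; beyond the scatter)) and (an at least 3.6-fold lower number from compound 2 to compound 3 (0.56 log units; beyond the scatter)) replace the whole group on the aromatic carbon, and compound 4 keeps the amide-type nitrogen and carbonyl of compound 3, so they suggest that it stays low. The nearest guide is a smaller step (a 5.0-fold lower number from compound 1 to compound 2 (0.70 log units; beyond the scatter)), where 1-methyl-1H-pyrazol-3-yl takes the place of phenyl on a nitrogen on an aromatic ring. Read backwards, that step brings phenyl in and raises the number, although the group and the place differ here. A modest rise is therefore expected (an at least 2.6-fold higher number from compound 3 to compound 4 (0.42 log units; beyond the scatter)). Compound 4 is estimated at 8 mL.min-1.g-1 (expected range 3 mL.min-1.g-1 to 25 mL.min-1.g-1).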

Compound 4, intrinsic clearance in microsomes in the Homo sapiens assay: 10 mL.min-1.g-1
The estimate for compound 4 lay 1.3-fold (0.10 log units) below the measured number; the measured number falls inside the stated range.
By their numbers in the Homo sapiens assay, from the lowest: compounds 4 and 2 (each within the scatter of the next); then compound 1. At a limit, below all of these: compound 3.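

Compound 3 stands at a limit and not a number in the Homo sapiens assay: the limit of < 3 mL.min-1.g-1 in the Homo sapiens assay, at which 1 of the 4 values shown sits.

In the Homo sapiens assay, phenyl in place of pyridin-3-yl on a carbonyl carbon gives an at least 3.3-fold higher number from compound 3 to compound 4 (0.52 log units; beyond the scatter), and in a physicochemical assay for solubility, read by LC-MS, in phosphate buffer, with a stated time of 24 h, at pH 7.4 (a lower number here means a less soluble compound, a higher number a more soluble compound), the same change, the first shown at this place, also moves the read-out: the measured solubility of compound 3, 12000 nM, and of compound 4, 2000 nM, a 6.0-fold lower number (0.78 log units; beyond the scatter)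

In the physicochemical assay compound 3 gives 12000 nM, and compound 4 gives 2000 nM.

In the Homo sapiens assay, benzamido in place of methyl(1-methyl-1H-pyrazol-3-yl)amino gives a 1.1-fold lower number from compound 2 to compound 4 (0.04 log units; within the scatter), whereas benzamido in place of methyl(phenyl)amino gives a 5.5-fold lower number from compound 1 to compound 4 (0.74 log units; beyond the scatter).

The compounds shown leave open how other groups on this carbonyl carbon, such as a pyrimidine ring, a morpholine or a short alkyl chain, would fare on clearance and solubility together. On these data alone, with compound 3 at a limit, the full size of its step to compound 4 also stays unknown.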